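Notes on a chloro to methoxy swap

The compounds below may be only part of what the source reports. "The series", "measured", "known", "first", "only" and "open" are said of these compounds alone.

Measured in a functional assay on PC-3 cells (Homo sapiens) for antiproliferative activity, read by MTT assay, with a stated time of 48 h; a higher number here means a weaker inhibitor, a lower number a stronger inhibitor:
- compound 1 `c1ccc(-c2nnc(-c3cn4ccccc4n3)o2)cc1`: 22200 nM
- compound 2 `Clc1ccc(-c2nnc(-c3cn4ccccc4n3)o2)cc1`: 33700 nM

Compound 2 stands at 33700 nM and compound 1 at 22200 nM, within the scatter of each other. The next compound, compound 3 `COc1ccc(-c2nnc(-c3cn4ccccc4n3)o2)cc1`, has methoxy in place of chloro on an aromatic carbon, para to a large group: methoxy in place of chloro on an aromatic carbon.

Within the data shown here, only one measured step bears on this change: a 1.5-fold higher number from compound 1 to compound 2 (0.18 log units; within the scatter). That step, chloro in place of hydrogen, lies within the scatter. Among the measured compounds shown here, no measured compound carries methoxy, so the evidence is indirect. In this assay, going by these compounds, no step beyond the scatter is therefore expected, and the direction stays open. The expected step is a 1.4-fold lower number from compound 2 to compound 3 (0.15 log units; within the scatter). For compound 3 the estimated value is 24000 nM, with an expected range from 9000 nM to 60000 nM.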

Compound 3, half-maximal inhibitory concentration: 13400 nM
For compound 3 the middle estimate is 1.8-fold (0.25 log units) above the measured one, and the stated range covers the measured number.
By their numbers in this assay, from the lowest: compounds 3, 1 and 2 (each within the scatter of the next, the first and the last beyond it).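

In this assay, among these compounds, the position para to a large group on the six-membered aromatic ring does distinguish between substituents: a 2.5-fold lower number from compound 2 to compound 3 (0.40 log units; beyond the scatter), the first step to lie beyond the scatter, though only a modest one. Set against the unsubstituted compound 1, the methoxy group does not stand apart: a 1.7-fold lower number from compound 1 to compound 3 (0.22 log units; within the scatter), so only the chloro and methoxy pair is resolved, not methoxy and hydrogen. Nothing at hand explains the gap between chloro and methoxy.

Still open, going by these compounds, is whether any group at this position, such as an amine, a hydroxyl or a longer ether chain like ethoxy, moves the value beyond the scatter from compound 1. Also open, on these data alone, is whether methoxy would give the same step from chloro elsewhere on this ring.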